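This account rests on a few compounds, and the source may have more. Where it says the series, first, only, none or still open, it means among the compounds named here.

Compound 1 `CC[C@H]1N[C@@H](CO)[C@@H](O)[C@H](O)[C@H]1O` gives 20.3% in an assay for inhibition of beta-galactosidase (Bos taurus), tested at 1000 uM (on this read-out higher numbers stand for more inhibition at the one concentration tested (going by the name of the read-out) and lower numbers for less inhibition), and compound 2 `CC[C@H]1NC[C@@H](O)[C@@H](O)[C@H](O)[C@H]1O` gives 12.1% in this assay. These two numbers lie within the usual scatter of each other, so neither compound can be called the stronger on this evidence. Compound 3 `CC[C@@H]1N[C@H](CC)[C@H](O)[C@@H](O)[C@@H]1O` has not yet been measured. Compared with compound 1 it carries methyl in place of hydroxy on a saturated chain carbon bound to a saturated ring carbon. Among the measured compounds shown here, no step between measured compounds is available to calibrate this change, so the expected step of a number 8.3 percentage points lower from compound 1 to compound 3 (within the scatter) is modest, downward, and not clearly beyond the scatter. Compound 3 is therefore estimated to give 12%, somewhere between 2% and 30%.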

Compound 3, a percentage reported as inhibition, at one concentration (the size of the read-out at that concentration, not a potency): 9.7%
For compound 3 the middle estimate is 2.3 percentage points above the measured one; measured number inside the range.
By their numbers in this assay, from the lowest: compounds 3, 2 and 1 (each within the scatter of the next, the first and the last beyond it).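

On the shared core, the change from hydroxy to methyl on a saturated chain carbon bound to a saturated ring carbon now has a measured size: in this assay the step is a number 10.6 percentage points lower from compound 1 to compound 3 (beyond the scatter) and gives the first calibration of this change. Read one bond further out, the same change is hydroxymethyl to ethyl, so this position registers the exchange on this read-out. Nothing measured here gives a reason for the step. As far as these compounds go, whether an amine, a carboxylic acid or a longer chain at this place would give a higher or lower number remains open.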